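Swapping the triazolylmethyl of compound 2 for a lactam alkene

A few compounds are considered here, and "the series" means these few. Any claim that something is new, unique, unknown or untested is made for them only; others in the source may bear on it.

The series shares one core carrying a branched side chain. Compound 1 `CC(C)C(Nc1nnc[nH]1)c1ccc(-c2ccc3cccc(F)c3c2)[nH]c1=O` gives 1.29 h in an ADME assay on microsomes from liver (Rattus norvegicus) for metabolic stability; a higher number here means that the compound lasts longer, a lower number that the compound disappears faster. Compound 2 `CC(C)C(Cc1nnc[nH]1)c1ccc(-c2ccc3cccc(F)c3c2)[nH]c1=O` gives 0.1 h in this assay, and the step of a 13-fold lower number from compound 1 to compound 2 (1.11 log units; beyond the scatter) sets it apart. Compound 3 `CCn1ncc2c(F)cc(-c3ccc(C(CC)(CC)c4nnc(C)[nH]4)c(=O)[nH]3)cc21` returns only a limit in this assay, > 3 h. Among the two plain numbers, compound 2 stands lowest, with compound 1 as its nearest neighbour at the higher end.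

Compound 4 `CC(C)C(/C=C1\CCNC1=O)c1ccc(-c2ccc3cccc(F)c3c2)[nH]c1=O` is compound 2 with a new group in the same position: a group of 7 heavy atoms (5 carbon, 1 nitrogen, 1 oxygen; one five-membered non-aromatic ring with 1 hetero atom) in place of a group of 6 heavy atoms (3 carbon, 3 nitrogen; one five-membered aromatic ring with 3 hetero atoms), on a saturated chain carbon bound to an aromatic carbon and a saturated chain carbon. Among the compounds with values here, no measured step involves the entering group, so the only step that bears on the position is the one from compound 1 to compound 2, which was large and downward. For compound 4 a change back toward longer half-life is plausible but not shown by any step, so the expected step of a 2.5-fold higher number from compound 2 to compound 4 (0.40 log units; beyond the scatter) is modest, with a wide range. Compound 4 is estimated at 0.25 h, between 0.06 h and 1 h.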

Compound 4, half-life: 0.345 h
Beside the measured number, compound 4's estimate is 1.4-fold (0.14 log units) below it; low and high end bracket the measured number.
By their numbers in this assay, from the lowest: compound 2; then compound 4; then compound 1. At a limit, above all of these: compound 3.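

In this assay, the position on a saturated chain carbon bound to an aromatic carbon and a saturated chain carbon tolerates a group with no triazole ring, and the five-membered non-aromatic ring with its exocyclic double bond gives a 3.5-fold higher number from compound 2 to compound 4 (0.54 log units; beyond the scatter). That recovery is only partial against the (4H-1,2,4-triazol-3-yl)amino group, with a 3.7-fold lower number from compound 1 to compound 4 (0.57 log units; beyond the scatter), so compound 1 keeps the longest half-life among the three plain numbers that differ at this position. Nothing measured here accounts for either step.

As far as these compounds go, whether a simple amine or a carboxylic acid at this position would fall nearer compound 1 or compound 2 remains open. Also open, from the compounds shown here alone, is how much of the change in compound 4 belongs to the double bond and how much to the ring, since both enter together in a single step.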